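The source may report more compounds than this note shows. Statements on the series, on what has been measured and on what is new or still open speak of the compounds shown alone.

Measured in a functional assay on HUVEC cells (Homo sapiens) for inhibition; on this read-out higher numbers stand for weaker inhibition and lower numbers for stronger inhibition:
- compound 1 `COc1cc(/C=C/C(=O)c2cccc(NC(=O)c3cccs3)c2)ccc1O`: 0.38 ug/mL
- compound 2 `COc1cc(/C=C/C(=O)c2cccc(NC(=O)c3ccc(Cl)cc3Cl)c2)ccc1O`: 0.4 ug/mL
- compound 3 `COc1cc(/C=C/C(=O)c2cccc(NC(=O)c3ccc(Cl)c(Cl)c3)c2)ccc1O`: 2.97 ug/mL

Compound 3 has the highest number of the three in this assay, which makes it the weakest inhibitor so far, and its gaps to the other two lie beyond the scatter. The next compound, compound 4 `CCCC(=O)Nc1cccc(C(=O)/C=C/c2ccc(O)c(OC)c2)c1`, carries propyl in place of 3,4-dichlorophenyl on a carbonyl carbon.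

All three measured steps involve this same carbonyl carbon. Going a 1.1-fold higher number from compound 1 to compound 2 (0.02 log units; within the scatter), the number barely moves. By contrast, going a 7.8-fold higher number from compound 1 to compound 3 (0.89 log units; beyond the scatter) and a 7.4-fold higher number from compound 2 to compound 3 (0.87 log units; beyond the scatter) gives modest rises. Among the measured compounds shown here, no measured compound has an open chain at this place, so the expectation is uncertain. Removing the group found in compound 3, at 2.97 ug/mL, is expected to give a modest move towards a lower number, meaning stronger inhibition, though no real change remains possible. The estimated step is a 2.5-fold lower number from compound 3 to compound 4 (0.39 log units; beyond the scatter). For compound 4 the estimated value is 1.2 ug/mL, with an expected range of 0.3 ug/mL to 5 ug/mL.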

Compound 4, half-maximal inhibitory concentration: 1.27 ug/mL
Compound 4: the middle estimate sits 1.1-fold (0.02 log units) below what was measured, and the stated range covers the measured number.
By their numbers in this assay, from the lowest: compounds 1 and 2 (each within the scatter of the next); then compound 4; then compound 3.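

In this assay, putting propyl in place of 3,4-dichlorophenyl gives a 2.3-fold lower number from compound 3 to compound 4 (0.37 log units; beyond the scatter) and so shows that this carbonyl carbon does not need a ring to keep inhibition, as the open chain does better than the weakest ring compound. The chain still falls short of the other two ring groups, with a 3.2-fold higher number from compound 2 to compound 4 (0.50 log units; beyond the scatter) and a 3.3-fold higher number from compound 1 to compound 4 (0.52 log units; beyond the scatter) on this read-out, so which ring stands here matters more than whether a ring is present at all. Nothing measured here explains these shifts.

Propyl is the only open chain among these compounds, so the effect of chain length remains unknown. A longer chain such as hexyl, or a chain ending in an amine or a carboxylic acid, might move the number towards those of compound 1 and compound 2, or away from them.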